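Cyclobutyl to cyclopentyl ester switch on a furanyl/thienyl pair

This account rests on a few compounds, and the source may have more. Where it says the series, first, only, none or still open, it means among the compounds named here.

Three compounds of a shared core have been run in an assay on membranes from CHO cells for displacement of a labelled ligand from adenosine receptor A1 (Homo sapiens), read by scintillation counting, with a stated time of 60 min, tested at 1 uM; on this read-out lower numbers stand for less inhibition and higher numbers for more inhibition at the one concentration tested (going by the name of the read-out). Compound 1 `CC1=C(C(=O)OC2CCC2)C(c2ccco2)NC(=O)N1` gives 19% in this assay. Compound 2 `CC1=C(C(=O)OC2CCCC2)C(c2ccco2)NC(=O)N1` differs by cyclopentyl in place of cyclobutyl on an oxygen next to a carbonyl group and gives 1% in this assay, so the step of a number 18 percentage points lower from compound 1 to compound 2 (beyond the scatter) reads as a modest loss. Compound 3 `CC1=C(C(=O)OC2CCC2)C(c2ccsc2)NC(=O)N1` differs from compound 1 by thiophen-3-yl in place of furan-2-yl on a saturated ring carbon; in this assay compound 3 gives 40%, the step of a number 21 percentage points higher from compound 1 to compound 3 (beyond the scatter) being a modest gain; compound 3 stands highest of the three measured numbers, with its steps to both other compounds beyond the scatter.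

Compound 4 `CC1=C(C(=O)OC2CCCC2)C(c2ccsc2)NC(=O)N1` has not yet been run in this assay. For the measured compounds named here, it differs from compound 3 by cyclopentyl in place of cyclobutyl on an oxygen next to a carbonyl group, which is the same change as the one from compound 1 to compound 2; the place lines of the two changes match word for word. The two cores differ as told by thiophen-3-yl in place of furan-2-yl on a saturated ring carbon.

Going by the values given here, only one measured instance of the change exists, so the expectation rests on a single step. For compound 4 a step of about a number 18 percentage points lower from compound 3 to compound 4 (beyond the scatter) in this assay is expected, resting on the step of a number 18 percentage points lower from compound 1 to compound 2 (beyond the scatter) seen when the same change was made on compound 1. Compound 4 is therefore estimated at 22% in this assay, within 5% to 40%.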

Compound 4, a percentage reported as inhibition, at one concentration (the size of the read-out at that concentration, not a potency): 5%
Compound 4: the middle estimate sits 17 percentage points above what was measured; the range from low to high includes it.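

In this assay, cyclopentyl in place of cyclobutyl on an oxygen next to a carbonyl group again lowers the number on the thiophen-3-yl core, with a number 35 percentage points lower from compound 3 to compound 4 (beyond the scatter), so the direction of the change carries over from the furan-2-yl pair but its size does not: the same change on two cores in this assay, a number 18 percentage points lower (beyond the scatter) from compound 1 to compound 2 and a number 35 percentage points lower (beyond the scatter) from compound 3 to compound 4, 17 percentage points apart, beyond the scatter of two such steps

The other change in this set of four behaves in the same way, since thiophen-3-yl in place of furan-2-yl on the cyclopentyl esters gives only a number 4 percentage points higher from compound 2 to compound 4 (within the scatter), and the clear gain seen on the cyclobutyl esters does not carry over: the same change on two cores in this assay, a number 21 percentage points higher (beyond the scatter) from compound 1 to compound 3 and a number 4 percentage points higher (within the scatter) from compound 2 to compound 4, 17 percentage points apart, beyond the scatter of two such steps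

The two changes therefore do not combine as independent steps in these four compounds, and the thiophen-3-yl gain appears only with cyclobutyl, but this rests on a single set of four percentages at one concentration and shows neither a rule for other cores nor any difference in potency.

Open, from the compounds shown here alone, is how the read-out responds to a cyclopropyl group or a longer open chain such as n-butyl on that oxygen, which would show whether cyclobutyl marks a narrow optimum. Also open, going by these compounds, is whether a phenyl or a pyridyl group on the saturated ring carbon shows the same dependence on the ester group.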